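The source may report more compounds than this note shows. Statements on the series, on what has been measured and on what is new or still open speak of the compounds shown alone.

Of the compounds shown here, three that share one core have so far been measured in a functional assay on MCF7 cells (Homo sapiens) for antiproliferative activity, read by MTT assay, with a stated time of 72 h; a higher number here means a weaker inhibitor, a lower number a stronger inhibitor. Compound 3 `COc1cc(-n2cnc3ccc(-c4ccc(C)cc4)cc32)cc(OC)c1OC`, which carries a 4-methylphenyl group, gives 110 nM, the lowest number of the three and so the strongest inhibitor among them. Compound 1 `COc1cc(-n2cnc3ccc(-c4ccc(C(C)=O)cc4)cc32)cc(OC)c1OC` gives 1540 nM, and compound 2 `COc1cc(-n2cnc3ccc(-c4cccc(C)c4C)cc32)cc(OC)c1OC` gives 2150 nM. These last two cannot be told apart: a 1.4-fold higher number from compound 1 to compound 2 (0.14 log units; within the scatter).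

The next compound is compound 4 `COc1cc(-n2cnc3ccc(-c4ccc(Cl)cc4Cl)cc32)cc(OC)c1OC`, with 2,4-dichlorophenyl in place of 4-methylphenyl on an aromatic carbon. Within the data shown here, no measured compound contains chlorine, so no step tests this change directly. Two large steps at the same place bear on it: a 14-fold lower number from compound 1 to compound 3 (1.15 log units; beyond the scatter) and a 20-fold lower number from compound 2 to compound 3 (1.29 log units; beyond the scatter). Among these three compounds, both groups other than 4-methylphenyl go with a higher number. The second step is the closer guide, since compound 2 also has two substituents on that ring and gives 2150 nM.

From the compounds shown here alone, a move to a higher number in this assay is therefore expected, probably a smaller one than these two steps, since the chlorine substituents are untested. The expected change is a 5.5-fold higher number from compound 3 to compound 4 (0.74 log units; beyond the scatter). For compound 4 the estimated value is 600 nM, within an expected range of 130 nM to 2700 nM.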

Compound 4, half-maximal inhibitory concentration: 5420 nM
For compound 4 the middle estimate is 9.0-fold (0.96 log units) below the measured one, outside the stated range (above it).
By their numbers in this assay, from the lowest: compound 3; then compounds 1 and 2 (each within the scatter of the next); then compound 4.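

In this assay, 2,4-dichlorophenyl in place of 4-methylphenyl gives a 49-fold higher number from compound 3 to compound 4 (1.69 log units; beyond the scatter), making compound 4 the weakest inhibitor of the four, so the position tolerates this group even less well than the two earlier replacements. The step from the other ring with two substituents gives a 2.5-fold higher number from compound 2 to compound 4 (0.40 log units; beyond the scatter), and the step from the acetyl-bearing ring gives a 3.5-fold higher number from compound 1 to compound 4 (0.55 log units; beyond the scatter), so the level shared by compound 1 and compound 2 is not an upper end for this position and the groups that lose activity still differ among themselves. Nothing measured here besides these numbers accounts for the order of the groups.

The compounds shown do not separate the contribution of each chlorine, since only 4-chlorophenyl and 2-chlorophenyl, each carrying a single chlorine, would show whether one of the two or their combination drives the rise in the number. From the compounds shown here alone, it also remains open whether any group other than 4-methylphenyl can match compound 3; 4-ethylphenyl with its longer chain and 4-aminophenyl with its amine would be examples.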